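Replacing 2-fluorophenyl with 4-methoxyphenyl in a small series

This account rests on a few compounds, and the source may have more. Where it says the series, first, only, none or still open, it means among the compounds named here.

In an ADME assay on Vero cells (Chlorocebus sabaeus) for cytotoxicity, read by resazurin assay, with a stated time of 72 h (on this read-out lower numbers stand for stronger inhibition and higher numbers for weaker inhibition), three related compounds have been measured so far. Compound 1 `Cc1ccc(C(=O)CCN2CCN(c3ccc(Cl)cc3)CC2)cc1` gives 184000 nM. Compound 2 `COc1ccccc1N1CCN(CCC(=O)c2ccc(F)cc2)CC1` gives 24000 nM. Compound 3 `O=C(CCN1CCN(c2ccccc2F)CC1)c1ccc(F)cc1` gives 49500 nM, the middle of the three numbers.

Compound 4 `COc1ccc(N2CCN(CCC(=O)c3ccc(F)cc3)CC2)cc1` has not been measured yet. It is compound 3 with 4-methoxyphenyl in place of 2-fluorophenyl on an amine nitrogen in a ring.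

Within the data shown here, only one measured step bears directly on this change. It is a 2.1-fold higher number from compound 2 to compound 3 (0.31 log units; beyond the scatter), and it comes from putting fluoro in place of methoxy on an aromatic carbon. Compound 4 swaps the fluoro of compound 3 for a methoxy-bearing group, so that step, read backwards, points towards a lower number. Among the measured compounds shown here, the support is thin, however, since the methoxy group of compound 4 does not sit where the one in compound 2 does, and no measurement yet tests that placement. For the measured compounds named here, compound 1 differs from compound 3 in more than one place, so it gives no clean step here.

A modest move towards a lower number, no larger than the measured one, therefore seems likely. The estimated step is a 1.5-fold lower number from compound 3 to compound 4 (0.19 log units; within the scatter). Compound 4 is expected at 32000 nM, with an estimated range from 12000 nM to 85000 nM.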

Compound 4, half-maximal inhibitory concentration: 31900 nM
Beside the measured number, compound 4's estimate is 1.0-fold (0.00 log units) above it; measured number inside the range.
By their numbers in this assay, from the lowest: compounds 2, 4 and 3 (each within the scatter of the next, the first and the last beyond it); then compound 1.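

Among these compounds, compound 4 is the only compound here that carries 4-methoxyphenyl on the amine nitrogen in a ring, so it gives the one reading of where the methoxy group sits in this assay: changing from 2-methoxyphenyl gives a 1.3-fold higher number from compound 2 to compound 4 (0.12 log units; within the scatter) and the two placements are not told apart. The change from 2-fluorophenyl gives a 1.6-fold lower number from compound 3 to compound 4 (0.19 log units; within the scatter) although the two earlier compounds are separated by a 2.1-fold higher number from compound 2 to compound 3 (0.31 log units; beyond the scatter) and so compound 4 cannot be grouped with either one, as it lies within the scatter of both. Nothing available explains these numbers at the level of cause.

Whether a group of a different kind on this phenyl ring, such as a carboxylic acid or an amine, would give a step beyond the scatter remains open, since the groups shown at this position are limited to fluoro and methoxy variants. Compound 1 differs from the others in more than one place, so what each of its differences contributes to its much higher number also remains unresolved.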